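This account rests on a few compounds, and the source may have more. Where it says the series, first, only, none or still open, it means among the compounds named here.

Measured compounds in a functional assay on A549 cells (Homo sapiens) for cytotoxicity, read by MTT assay, with a stated time of 48 h; a higher number here means a weaker inhibitor, a lower number a stronger inhibitor:

compound 1, `CCOC(=O)c1c(-c2c(Cl)c3cc(C)ccc3oc2=O)nn(-c2cccc(C)c2)c1C(=O)OCC`: 115000 nM
compound 2, `CCOC(=O)c1c(-c2c(Cl)c3cc(C)ccc3oc2=O)nn(-c2cccc(Cl)c2)c1C(=O)OCC`: 128000 nM
compound 3, `COC(=O)c1c(-c2cc3ccccc3oc2=O)nn(-c2cccc(C)c2)c1C(=O)OC`: 51000 nM

Compounds 1 and 2 share one core; compound 3 carries another, and the difference between the two cores is not broken down here. Within the first pair the single change is chloro in place of methyl on an aromatic carbon, and in this assay it gave a 1.1-fold higher number from compound 1 to compound 2 (0.05 log units; within the scatter). Compound 3 stands at the lowest of the three numbers, beyond the scatter from both compound 1 and compound 2.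

Compound 4, `COC(=O)c1c(-c2cc3ccccc3oc2=O)nn(-c2cccc(Cl)c2)c1C(=O)OC`, is not yet measured. It differs from compound 3 by chloro in place of methyl on an aromatic carbon, the same change as that between compound 1 and compound 2, at a place described in identical words. Within the data shown here, with only one earlier example of this change, and that one within the scatter, the step from compound 3 to compound 4 is expected to be small as well, a 1.1-fold higher number from compound 3 to compound 4 (0.04 log units; within the scatter), resting on a 1.1-fold higher number from compound 1 to compound 2 (0.05 log units; within the scatter). The number for compound 4 in this assay is therefore estimated at 56000 nM, with a range from 30000 nM to 110000 nM, which allows for the core of compound 3 responding differently from that of compound 1.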

Compound 4, half-maximal inhibitory concentration: 30000 nM
Compound 4: middle estimate off by 1.9-fold (0.27 log units), on the high side; low and high end bracket the measured number.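

In this assay chloro in place of methyl on an aromatic carbon gives a 1.7-fold lower number from compound 3 to compound 4 (0.23 log units; within the scatter) and so stays within the usual scatter on this core as well. Set beside the earlier step, the change carries across the two cores with no difference that repeated measurement could separate: the same change on two cores in this assay, a 1.1-fold higher number (0.05 log units; within the scatter) from compound 1 to compound 2 and a 1.7-fold lower number (0.23 log units; within the scatter) from compound 3 to compound 4, 1.9-fold (0.28 log units) apart, within the scatter of two such steps. This shows that swapping 3-methylphenyl for 3-chlorophenyl has no effect beyond the scatter on either core, but with a single pair per core it does not show that the two cores respond identically, and the gap between the two steps carries no meaning of its own.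

The compounds shown leave open whether another group in this place, such as an amine, a carboxylic acid or a methoxy group, would move the number beyond the scatter. Among these compounds, also open is which part of the difference between the two cores goes with the distance between compound 3 and compounds 1 and 2, as no single-change pair here connects the cores.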